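The compounds below may be only part of what the source reports. "The series", "measured", "known", "first", "only" and "open" are said of these compounds alone.

Three compounds carry numbers in a functional assay on the whole organism with Mus musculus as the target; on this read-out lower numbers stand for an effect already at smaller amounts and higher numbers for an effect only at larger amounts of compound. Compound 1 `O=c1oc2cccnc2n1CCN1CCN(c2ccc(F)cc2)CC1` gives 41.3 mg/kg in this assay, the highest of the three. Compound 2 `O=c1oc2ccccc2n1CCN1CCN(c2cccc(C(F)(F)F)c2)CC1` gives 30.2 mg/kg in this assay, a number within the scatter of that for compound 1. Compound 3 `O=c1oc2cccnc2n1CN1CCN(c2cccc(Cl)c2)CC1` gives 10.5 mg/kg in this assay, a number beyond the scatter and below that of compound 1; compound 3 differs from compound 1 in more than one place, so this gap cannot be tied to a single change.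

Compound 4 `CN1CCN(CCn2c(=O)oc3cccnc32)CC1` has no number yet. Against compound 1 it shows (methyl in place of 4-fluorophenyl on an amine nitrogen in a ring). Among the measured compounds shown here, no pair of measured compounds differs in this one place, so no measured step speaks directly to it. Each measured compound carries a substituted phenyl on the amine nitrogen in a ring; compound 4 alone does not. The expected step is a 2.1-fold higher number from compound 1 to compound 4 (0.31 log units; beyond the scatter), toward a higher number and beyond the scatter. Compound 4 is accordingly estimated at 85 mg/kg in this assay, with a range from 30 mg/kg to 250 mg/kg.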

Compound 4, dose for half-maximal effect: > 25 mg/kg
Compound 4 ended at the assay's limit; the forecaster's own chance of this, stated with the estimate: 30%; the middle value is on the limit's open side.
By their numbers in this assay, from the lowest: compound 3; then compounds 2 and 1 (each within the scatter of the next).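

In this assay, among the compounds shown here, compound 4 gives > 25 mg/kg, a limit of the assay and not a number, so no step from compound 1 to compound 4 can be read. The compounds shown leave open what methyl in place of 4-fluorophenyl on an amine nitrogen in a ring does to the number in this assay.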